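This account rests on a few compounds, and the source may have more. Where it says the series, first, only, none or still open, it means among the compounds named here.

Working notes on the series.

Three compounds have a number in an assay for binding affinity to Alpha-1A adrenergic receptor (Homo sapiens), read by radioligand binding; a higher number here means a weaker inhibitor, a lower number a stronger inhibitor. Compound 1 `CSc1ccc(C)cc1NCC1=NCCN1` gives 20.9 nM. Compound 2 `Cc1ccc(S(C)(=O)=O)c(NCC2=NCCN2)c1` gives 776 nM, and compound 3 `CS(=O)(=O)c1cc(F)ccc1NCC1=NCCN1` gives 661 nM. The values of compound 2 and compound 3 lie within the scatter of each other, so no order between them is claimed. The difference between the cores of compound 2 and compound 3 is not broken down here.

One step is counted among the measured compounds: a 37-fold lower number from compound 2 to compound 1 (1.57 log units; beyond the scatter). The change is methylsulfanyl in place of methylsulfonyl on an aromatic carbon.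

Compound 4 `CSc1cc(F)ccc1NCC1=NCCN1` has not yet been measured in this assay. It differs from compound 3 by methylsulfanyl in place of methylsulfonyl on an aromatic carbon. Among the measured compounds shown here, this is the same kind of change as the one from compound 2 to compound 1, but not the same: in compound 2 the site is para to a methyl group, whereas in compound 3 it is meta to a fluoro group, and the core differs in a way that is not broken down here.

For the measured compounds named here, with only one earlier example of this change, the expectation rests on compound 3 at 661 nM and on the single step of a 37-fold lower number from compound 2 to compound 1 (1.57 log units; beyond the scatter). Going by the values given here, a step of similar size is expected, a 26-fold lower number from compound 3 to compound 4 (1.42 log units; beyond the scatter), with wide margins because only one precedent exists and the surroundings of the site differ. Compound 4 is therefore estimated at 25 nM, between 8 nM and 80 nM.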

Compound 4, inhibition constant: 20.9 nM
Beside the measured number, compound 4's estimate is 1.2-fold (0.08 log units) above it, and the stated range covers the measured number.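

In this assay, methylsulfanyl in place of methylsulfonyl on an aromatic carbon again gives a large step, a 32-fold lower number from compound 3 to compound 4 (1.50 log units; beyond the scatter), and the two steps agree in size: the same change on two cores in this assay, a 37-fold lower number (1.57 log units; beyond the scatter) from compound 2 to compound 1 and a 32-fold lower number (1.50 log units; beyond the scatter) from compound 3 to compound 4, 1.2-fold (0.07 log units) apart, within the scatter of two such steps.

Across these two cores, then, the size of the step carries over, even though the cores differ, with a methyl group in compound 2 and a fluoro group in compound 3, and neither pair goes against this. What is shown is agreement between two pairs on two cores in one assay, which is no rule for other cores, and it gives no reason why the step is so large.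

The compounds shown leave open whether the step keeps its size when the methyl or fluoro group gives way to something quite different, such as an amine or a carboxylic acid. They also leave open how far the sulfur substituent itself can vary, for instance with a longer chain such as ethylsulfanyl, or with the methylsulfinyl group that stands between the two groups compared here in its oxygen count.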